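Series notes: furoyl amide in place of diacetyl on the core

The source may hold more compounds than are shown below. What is called first, only, known or untested is meant among the compounds shown, and "the series" means these compounds.

Measured in an assay on CHO cells for displacement of a labelled ligand from adenosine receptor A1 (Homo sapiens), tested at 10 uM; a lower number here means less inhibition, a higher number more inhibition at the concentration tested (going by the name of the read-out):
compound 1, `CC(=O)Nc1nn(-c2ccccc2)c(=O)c2ccccc12`, gives 52%.
compound 2, `CC(=O)N(C(C)=O)c1nn(-c2ccccc2)c(=O)c2ccccc12`, gives 47%.

Going by the values given here, compound 2 sits at one end of the two numbers, with compound 1 its only neighbour; the step of a number 5 percentage points lower from compound 1 to compound 2 (within the scatter) lies within the scatter, so the two compounds are not told apart by this assay. Compound 3, `O=C(Nc1nn(-c2ccccc2)c(=O)c2ccccc12)c1ccco1`, is not yet measured. Its change from compound 2 is ((furan-2-yl)carbonyl)amino in place of diacetylamino on an aromatic carbon. Among the compounds with values here, no measured step touches this change directly: the one step available, a number 5 percentage points lower from compound 1 to compound 2 (within the scatter), concerns acetyl in place of hydrogen on the amide-type nitrogen and stayed within the scatter. Compound 3 keeps one hydrogen-bond donor on that nitrogen, as compound 1 does, so a number near those of compound 1 and compound 2 is expected, with nothing beyond the scatter. Compound 3 is estimated at 50%, between 28% and 70%. The step so expected is a number 3 percentage points higher from compound 2 to compound 3 (within the scatter).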

Compound 3, a percentage reported as inhibition, at one concentration (the size of the read-out at that concentration, not a potency): 23%
Compound 3: middle estimate off by 27 percentage points, on the high side; measured number below the stated range.
By their numbers in this assay, from the lowest: compound 3; then compounds 2 and 1 (each within the scatter of the next).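

In this assay, this position proves sensitive to the group on the carbonyl carbon: furan-2-yl in place of methyl gives a number 29 percentage points lower from compound 1 to compound 3 (beyond the scatter), whereas the earlier acetyl in place of hydrogen on the amide-type nitrogen stayed at a number 5 percentage points lower from compound 1 to compound 2 (within the scatter). The exchange of diacetylamino for ((furan-2-yl)carbonyl)amino on the aromatic carbon gives a number 24 percentage points lower from compound 2 to compound 3 (beyond the scatter), and since compound 1 and compound 3 both keep the amide hydrogen, that hydrogen alone does not hold the number up. Nothing available bears on the reason for this fall.

The compounds shown leave open whether the fall belongs to the furan-2-yl ring as such or to any group other than methyl on that carbonyl carbon. A phenyl ring or a longer alkyl chain at that carbon would separate the two readings.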